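Trimming an Isopropyl Ketone Down to an Acetyl Group

The source may hold more compounds than are shown below. What is called first, only, known or untested is meant among the compounds shown, and "the series" means these compounds.

Compound 1 `COc1ccc(C(=O)O)cc1OCCCCOc1ccc(C(=O)C(C)C)c(O)c1C` gives 59.9% in an assay on HEK293 cells for positive allosteric modulation of metabotropic glutamate receptor 3 (Rattus norvegicus), read by thallium flux, with a stated time of 2.5 min; a higher number here means a larger maximal response, a lower number a smaller maximal response. Compound 2 `COc1ccc(C(=O)O)cc1OCCCCOc1ccc(C(C)=O)c(O)c1C` differs from it only by methyl in place of isopropyl on a carbonyl carbon; in this assay compound 2 gives 34.8%, which is a number 25.1 percentage points lower from compound 1 to compound 2 (beyond the scatter). Compound 3 `Cc1c(OCCCCOc2ccc(F)c(C(=O)O)c2)ccc(C(=O)C(C)C)c1O` rests on a different core, and the difference between the two cores is not broken down here. In this assay compound 3 gives 31.3%, a value close to that of compound 2. Compound 4 `CC(=O)c1ccc(OCCCCOc2ccc(F)c(C(=O)O)c2)c(C)c1O` is derived from compound 3 by the same change, (methyl in place of isopropyl on a carbonyl carbon), at the same place. A smaller drop is expected for compound 4, estimated as a number 16.3 percentage points lower from compound 3 to compound 4 (beyond the scatter), because the same change gave a number 25.1 percentage points lower from compound 1 to compound 2 (beyond the scatter) while compound 3 already starts low at 31.3%. Compound 4 is therefore expected to reach about 15%, most likely between 3% and 30%.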

Compound 4, largest response reached (reported as percent of maximum), in percent of the reference or control that the assay uses: 16.8%
The estimate for compound 4 lay 1.8 percentage points below the measured number, within the range that was stated.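

Putting methyl in place of isopropyl on a carbonyl carbon also lowers the response on the core of compound 3 in this assay, giving a number 14.5 percentage points lower from compound 3 to compound 4 (beyond the scatter). Set beside the earlier step, the change points the same way on both cores, and the two sizes cannot be told apart: the same change on two cores in this assay, a number 25.1 percentage points lower (beyond the scatter) from compound 1 to compound 2 and a number 14.5 percentage points lower (beyond the scatter) from compound 3 to compound 4, 10.6 percentage points apart, within the scatter of two such steps. This shows that the change carried over between these two cores, but two pairs cannot show that it would carry over to any other core, nor do they explain why the response falls.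

The compounds shown leave open where ethyl or cyclopropyl on that carbonyl carbon would fall. They also leave open whether an amine in place of the carboxylic acid would alter the step.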